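Compound 2 and the step to compound 3

The source may hold more compounds than are shown below. What is called first, only, known or untested is meant among the compounds shown, and "the series" means these compounds.

Measured in an ADME assay on Vero cells (Chlorocebus sabaeus) for cytotoxicity, read by resazurin assay, with a stated time of 72 h; a higher number here means a weaker inhibitor, a lower number a stronger inhibitor:
Compound 1 `O=C(CCN1CCN(c2ccc(C(F)(F)F)cc2)CC1)c1ccccc1`: 15700 nM
Compound 2 `COc1ccc(C(=O)CCN2CCN(c3ccc(C(F)(F)F)cc3)CC2)cc1OC`: 243000 nM

In this assay, compound 2 holds the higher of the two numbers, and compound 1 lies beyond the scatter from it. The change now in view is 4-bromophenyl in place of 3,4-dimethoxyphenyl on a carbonyl carbon, and it gives compound 3 `O=C(CCN1CCN(c2ccc(C(F)(F)F)cc2)CC1)c1ccc(Br)cc1`. Among the measured compounds shown here, one measured step bears on it: a 15-fold higher number from compound 1 to compound 2 (1.19 log units; beyond the scatter), a large step that came with 3,4-dimethoxyphenyl in place of phenyl on a carbonyl carbon. The 3,4-dimethoxyphenyl now leaves, so a large step toward a lower number is expected, of about that size. For the measured compounds named here, no compound carrying 4-bromophenyl has been measured, so this rests on one step only and the range stays wide. The expected step is a 16-fold lower number from compound 2 to compound 3 (1.21 log units; beyond the scatter). The estimate for compound 3 is 15000 nM, with an expected range of 4000 nM to 60000 nM.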

Compound 3, half-maximal inhibitory concentration: 78800 nM
Beside the measured number, compound 3's estimate is 5.3-fold (0.72 log units) below it, and the stated range ends below it.
By their numbers in this assay, from the lowest: compound 1; then compound 3; then compound 2.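

In this assay, the aryl group on the carbonyl carbon proved sensitive to a lone halogen as well as to the two methoxy groups: bromo in place of hydrogen on an aromatic carbon gave a 5.0-fold higher number from compound 1 to compound 3 (0.70 log units; beyond the scatter). Exchanging 3,4-dimethoxyphenyl for 4-bromophenyl gave a 3.1-fold lower number from compound 2 to compound 3 (0.49 log units; beyond the scatter), so this change took back only part of the rise that came with 3,4-dimethoxyphenyl, and compound 3 sits between compound 1 and compound 2. Nothing available bears on what sets this order among the three groups.

From the compounds shown here alone, what a chloro group, a nitrile or a single methoxy group on that phenyl ring would do remains open. So does whether an amine or a carboxylic acid there would bring the number closer to that of compound 1 or of compound 2.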